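Cytotoxicity of a Fourth Amide Variant, Judged from Three Limits

This account rests on a few compounds, and the source may have more. Where it says the series, first, only, none or still open, it means among the compounds named here.

Compound 1, `Cc1cc(CNC(=O)c2cc3nc(C)c([C@H](OC(C)(C)C)C(=O)O)c(-c4cc(F)c5c(c4C)CCCO5)n3n2)ccc1F`, in an ADME assay on MT2 cells (Homo sapiens) for cytotoxicity (on this read-out lower numbers stand for higher toxicity in this test and higher numbers for lower toxicity in this test), gives > 40000 nM, which is a limit of the assay and not a number.
Compound 2, `Cc1nc2cc(C(=O)NCc3ccc(F)cc3-n3cncn3)nn2c(-c2cc(F)c3c(c2C)CCCO3)c1[C@H](OC(C)(C)C)C(=O)O`, in this assay gives > 40000 nM, again a limit.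
Compound 3, `Cc1nc2cc(C(=O)NCC3CCCCC3)nn2c(-c2cc(F)c3c(c2C)CCCO3)c1[C@H](OC(C)(C)C)C(=O)O`, in this assay gives > 40000 nM, again a limit.

Compound 1 therefore stands at the edge of what this assay can report, together with the other two, as the limit of > 40000 nM in this assay, at which 3 of the 3 values shown sit, shows. The steps a step that the two limits leave unreadable from compound 1 to compound 2 and a step that the two limits leave unreadable from compound 1 to compound 3 cannot be sized, because both ends are limits. Compound 4, `Cc1nc2cc(C(=O)NCC3CCOCC3)nn2c(-c2cc(F)c3c(c2C)CCCO3)c1[C@H](OC(C)(C)C)C(=O)O`, differs from compound 1 by oxan-4-yl in place of 4-fluoro-3-methylphenyl on a saturated chain carbon bound to an amide-type nitrogen. The two measured steps, which also exchange the group on that carbon, give no readable size, so no step beyond the scatter is expected and compound 4 is estimated at 60000 nM, within 30000 nM to 150000 nM. That estimate means an expected step that the limit leaves unreadable from compound 1 to compound 4.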

Compound 4, half-maximal cytotoxic concentration: > 40000 nM
Compound 4 gave a limit, no number; the forecaster's own chance of this, stated with the estimate: 85%; the middle value is on the limit's open side.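

Compound 4 also gives only a limit, so its steps from compound 1, compound 2 and compound 3 cannot be read: the limit of > 40000 nM in this assay, at which 4 of the 4 values shown sit. On these data alone, whether the exchanged group changes the outcome in this assay at all stays open, since none of the four compounds gives a number.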